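From 4-fluorobenzyl to propyl on the shared core

A few compounds are considered here, and "the series" means these few. Any claim that something is new, unique, unknown or untested is made for them only; others in the source may bear on it.

Of the compounds shown here, three have values so far in an ADME assay on KB cells (Homo sapiens) for cytotoxicity; on this read-out higher numbers stand for an effect only at larger amounts of compound and lower numbers for an effect already at smaller amounts. Compound 1 (`CCOC(=O)N1[C@@H]2C=C[C@@](OC)(C(=O)c3c2cc(OC)c(OC)c3OCc2ccc(F)cc2)N1C(=O)OCC`) gives 51.8 ug/mL. Compound 2 (`COc1cc2c(c(OCc3ccccc3)c1OC)C(=O)[C@]1(OC)C=C[C@H]2N(C(=O)OCC(C)C)N1C(=O)OCC(C)C`) gives 94 ug/mL. Compound 3 (`COC(=O)N1[C@@H]2C=C[C@@](OC)(C(=O)c3c2cc(OC)c(OC)c3OCc2ccc(F)cc2)N1C(=O)OC`) gives 56.6 ug/mL. Compound 1 stands within the scatter of both of the others, so the three values form a single group and no order can be read among them.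

Compound 4 (`CCCOc1c(OC)c(OC)cc2c1C(=O)[C@]1(OC)C=C[C@H]2N(C(=O)OCC)N1C(=O)OCC`) has not yet been measured. Its structural change from compound 1 is ethyl in place of 4-fluorophenyl on a saturated chain carbon bound to an oxygen on an aromatic ring. In words, ethyl takes the place of 4-fluorophenyl on a saturated chain carbon bound to an oxygen on an aromatic ring, so 4-fluorobenzyl becomes propyl.

Among the compounds with values here, no measured compound lacks the aromatic ring on this chain, which leaves the series without a direct precedent for the change. The expectation rests only on how close compound 1 at 51.8 ug/mL and compound 2 at 94 ug/mL stand. No step beyond the scatter is expected in this assay, and the estimated step is a 1.4-fold higher number from compound 1 to compound 4 (0.13 log units; within the scatter). For compound 4 the expected value is 70 ug/mL, with an estimated range of 30 ug/mL to 150 ug/mL.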

Compound 4, concentration for half-maximal effect: > 300 ug/mL
Compound 4 ended at the assay's limit (the forecaster's own chance of this, stated with the estimate: 15%); middle value at least 4.2-fold (0.63 log units) from the limit.
By their numbers in this assay, from the lowest: compounds 1, 3 and 2 (each within the scatter of the next). At a limit, above all of these: compound 4.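

In this assay, within the data shown here, the change from 4-fluorobenzyl to propyl gives an at least 5.7-fold higher number from compound 1 to compound 4 (0.76 log units; beyond the scatter), the first step that can be read at this position, on a saturated chain carbon bound to an oxygen on an aromatic ring. Compound 4 stands at a limit of the assay and not at a number, so this step gives only a lower bound on the true gap: the limit of > 300 ug/mL in this assay, at which 1 of the 4 values shown sits. The position is therefore not indifferent in this assay, and for this one pair, keeping the aromatic ring of the 4-fluorobenzyl group goes with an effect at the amounts where compound 1 gives 51.8 ug/mL, while the propyl group does not.

The compounds shown do not separate the loss of the aromatic ring from the shortening of the group, and the fluorine has no direct partner on the same carbamates, since benzyl appears only in compound 2, which also differs there. A phenethyl group, a longer chain such as hexyl, or a chain ending in an amine at this position would begin to settle these questions.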